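The source may report more compounds than this note shows. Statements on the series, on what has been measured and on what is new or still open speak of the compounds shown alone.

Three compounds that share one core have been examined in an ADME assay on Vero cells (Chlorocebus sabaeus) for cytotoxicity, read by MTT assay, with a stated time of 72 h; a lower number here means a stronger inhibitor, a higher number a weaker inhibitor. Compound 1 `O=C(c1ccncc1)N1N=C(c2cc3ccccc3o2)CC1c1cccc([N+](=O)[O-])c1` gives in this assay only a limit, > 240000 nM. Compound 2 `O=C(c1ccncc1)N1N=C(c2cc3ccccc3o2)CC1c1ccc(O)cc1` likewise gives only a limit, > 200000 nM. For the measured compounds named here, the one step measured between them, a step that the two limits leave unreadable from compound 1 to compound 2, cannot be read because both of its ends are limits, as the limit of > 240000 nM in this assay, at which 1 of the 3 values shown sits, and the limit of > 200000 nM in this assay, at which 1 of the 3 values shown sits, show. Compound 3 `CCn1cc(C(=O)N2N=C(c3cc4ccccc4o3)CC2c2ccccc2O)c(=O)c2ccc(C)nc21`, which carries a different acyl group on the core, again gives only a limit, > 157000 nM, as the limit of > 157000 nM in this assay, at which 1 of the 3 values shown sits, records. So compound 3 stands where the other two stand: no number, only a limit.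

Compound 4 `CCn1cc(C(=O)N2N=C(c3cc4ccccc4o3)CC2c2ccccc2OC)c(=O)c2ccc(C)nc21` differs from compound 3 by methyl in place of hydrogen on an oxygen on an aromatic ring, so hydroxy becomes methoxy. Going by the values given here, no measured step bears on this change, since the single step available is unreadable. The estimated step that the limit leaves unreadable from compound 3 to compound 4 is therefore expected to stay within the scatter, most likely another limit. Compound 4 is expected to give about 200000 nM, between 80000 nM and 500000 nM.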

Compound 4, half-maximal inhibitory concentration: > 187000 nM
Compound 4: only a limit was reported; the forecaster's own chance of this, stated with the estimate: 80%; the middle value does not contradict the limit.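

Compound 3 and compound 4 both give only limits, so the step from hydroxy to methoxy between them cannot be read. The compounds shown leave open where any of the four would actually reach half-maximal inhibition, and so whether any change on the shared core alters cytotoxicity.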